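The source may report more compounds than this note shows. Statements on the series, on what has been measured and on what is new or still open speak of the compounds shown alone.

Compound 1, with the structure `O=C(O)/C=C/C(=O)c1ccccc1`, was examined in a functional assay on K562 cells (Homo sapiens) for inhibition, read by MTT assay, with a stated time of 72 h (on this read-out higher numbers stand for weaker inhibition and lower numbers for stronger inhibition), where compound 1 gives 30200 nM. Among the measured compounds shown here, of the two numbers recorded in this assay, compound 1 holds the highest; the only other measured compound, compound 2, `CCc1ccc(C(C)C)cc1C(=O)/C=C/C(=O)O`, gives 1360 nM, a number far enough below that of compound 1 to lie beyond the scatter. The next compound of the series is compound 3, `O=C(O)/C=C/C(=O)c1ccc(Br)cc1`, not yet measured in this assay. It differs from compound 1 by a single change: bromo in place of hydrogen on an aromatic carbon. No comparison between compound 1 and compound 3 has been made yet, so any step can only be anticipated. Given that compound 2, a more heavily substituted analogue, reaches 1360 nM, a modest move toward stronger inhibition is expected for compound 3, though one smaller than that seen for compound 2. Compound 3 is thus estimated at 10000 nM, within a range from 4000 nM to 30000 nM, meaning an expected step of a 3.0-fold lower number from compound 1 to compound 3 (0.48 log units; beyond the scatter).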

Compound 3, half-maximal inhibitory concentration: 11200 nM
Compound 3: middle estimate off by 1.1-fold (0.05 log units), on the low side; the measured number falls inside the stated range.
By their numbers in this assay, from the lowest: compound 2; then compound 3; then compound 1.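

In this assay, a single bromo group in place of hydrogen on the aromatic ring, para to a group of 7 heavy atoms, is enough on its own to give a modest step beyond the scatter: a 2.7-fold lower number from compound 1 to compound 3 (0.43 log units; beyond the scatter). Among the compounds shown here, this is the first change that can be read at one place on the core of compound 1, whereas compound 2 differs from compound 1 in more than one place and offers no such reading. Nothing measured here explains the step. From the compounds shown here alone, it remains open whether the step is particular to bromo or would also come with another group at this place, such as chloro, methoxy or an amine. Going by these compounds, it is equally open whether bromo on another carbon of the ring would give a step of similar size.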